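From dimethoxyphenyl to bromophenyl in a flat series

A few compounds are considered here, and "the series" means these few. Any claim that something is new, unique, unknown or untested is made for them only; others in the source may bear on it.

In a functional assay on MCF7 cells (Homo sapiens) for cytotoxicity, read by MTT assay, with a stated time of 72 h (a higher number here means a weaker inhibitor, a lower number a stronger inhibitor), compound 1 (`COc1cc2ncnc(Nc3ccc(F)c(Cl)c3)c2cc1NC(=O)/C=C/c1ccccc1[N+](=O)[O-]`) gives 36500 nM and compound 2 (`COc1ccc(/C=C/C(=O)Nc2cc3c(Nc4ccc(F)c(Cl)c4)ncnc3cc2OC)c(OC)c1`) gives 36600 nM while compound 3 (`COc1ccc(OC)c(/C=C/C(=O)Nc2cc3c(Nc4ccc(F)c(Cl)c4)ncnc3cc2O[C@H]2CCOC2)c1`) gives 36300 nM as its number. Compound 3 therefore stands level with the other two, all three numbers lying within the scatter of each other. Compound 4 (`O=C(/C=C/c1ccc(Br)cc1)Nc1cc2c(Nc3ccc(F)c(Cl)c3)ncnc2cc1O[C@H]1CCOC1`) carries 4-bromophenyl in place of 2,5-dimethoxyphenyl on a double-bonded chain carbon bound to a double-bonded chain carbon. Among the measured compounds shown here, the only measured step at this place is a 1.0-fold higher number from compound 1 to compound 2 (0.00 log units; within the scatter) with 2,4-dimethoxyphenyl in place of 2-nitrophenyl, and it lies within the scatter. For the measured compounds named here, no measured compound carries 4-bromophenyl, so this single step is a thin guide. In this assay no step beyond the scatter is expected, and the estimated step is a 1.1-fold lower number from compound 3 to compound 4 (0.04 log units; within the scatter) with no firm direction. Compound 4 is estimated at 33000 nM with an expected range from 14000 nM to 65000 nM in this series.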

Compound 4, half-maximal inhibitory concentration: 32400 nM
Beside the measured number, compound 4's estimate is 1.0-fold (0.01 log units) above it, within the range that was stated.
By their numbers in this assay, from the lowest: compounds 4, 3, 1 and 2 (each within the scatter of the next).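

In this assay, the exchange of 2,5-dimethoxyphenyl for 4-bromophenyl on a double-bonded chain carbon bound to a double-bonded chain carbon gives a 1.1-fold lower number from compound 3 to compound 4 (0.05 log units; within the scatter), so this change stays within the scatter. Among the compounds shown here, this is the first step at this place to bring in a halogen and to remove the methoxy groups altogether: the entering group has fewer heavy atoms and no hydrogen-bond acceptors, yet the number does not move beyond the scatter. No supporting data are available to explain this result.

It remains open whether any group at this place can shift the number beyond the scatter, since all the groups shown here are substituted phenyl rings. An amine or a carboxylic acid in place of the ring would test this.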